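A Methoxy Group Weighed on Two Related Cores

The compounds below may be only part of what the source reports. "The series", "measured", "known", "first", "only" and "open" are said of these compounds alone.

Compound 1 `N#CCCn1nc(-c2ccc(OCc3ccccc3)cc2)oc1=O` gives the lowest number of the three measured compounds in an assay for inhibition of Amine oxidase [flavin-containing] B (Rattus norvegicus) (a lower number here means a stronger inhibitor, a higher number a weaker inhibitor), where compound 1 reaches 2.2 nM. Compound 2 `COc1ccc(COc2ccc(-c3nn(CCC#N)c(=O)o3)cc2)cc1` differs from it by methoxy in place of hydrogen on an aromatic carbon, and in this assay compound 2 gives 27 nM. That single change produced a 12-fold higher number from compound 1 to compound 2 (1.09 log units; beyond the scatter).

Compound 3 `N#CCCN1N=C(c2ccc(OCc3ccccc3)cc2)OCC1=O` is built on another core; the difference between the two cores is not broken down here. In this assay compound 3 gives 18 nM, a value within the scatter of that of compound 2, and well beyond the scatter away from that of compound 1.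

Compound 4 `COc1cccc(COc2ccc(C3=NN(CCC#N)C(=O)CO3)cc2)c1` is not yet measured and differs from compound 3 by methoxy in place of hydrogen on an aromatic carbon. Among the measured compounds shown here, this is the same kind of change as the one between compound 1 and compound 2, but not the same change: in compound 2 the methoxy sits para to a large group, whereas in compound 4 it sits meta to a large group. For the measured compounds named here, the only measured precedent, a 12-fold higher number from compound 1 to compound 2 (1.09 log units; beyond the scatter), points toward a higher number, so compound 4 is expected to lose potency relative to compound 3, by an estimated 5.0-fold higher number from compound 3 to compound 4 (0.70 log units; beyond the scatter). The place of the group is not the same as in that precedent. The expected step is therefore kept somewhat smaller than the measured one, with a wide range. Compound 4 is therefore estimated at 90 nM in this assay, between 25 nM and 350 nM.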

Compound 4, half-maximal inhibitory concentration: 68 nM
Compound 4: middle estimate off by 1.3-fold (0.12 log units), on the high side, within the range that was stated.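

In this assay, methoxy in place of hydrogen on an aromatic carbon again gives a higher number on the second core, a 3.8-fold higher number from compound 3 to compound 4 (0.58 log units; beyond the scatter), so the direction of the step carries over while its size does not: the same change on two cores in this assay, a 12-fold higher number (1.09 log units; beyond the scatter) from compound 1 to compound 2 and a 3.8-fold higher number (0.58 log units; beyond the scatter) from compound 3 to compound 4, 3.2-fold (0.51 log units) apart, beyond the scatter of two such steps

This does not show that the core alone sets the size of the step, since the two pairs differ in the place of the methoxy as well: in compound 4 it sits meta to a large group, and in compound 2 it does not. With one pair on each core, the result holds for these four compounds only and gives no general rule for the series, though no compound shown goes against the shared direction.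

The compounds shown leave open whether a methoxy set in the same place on both cores would give steps of the same size, which would separate the part played by the core from the part played by the place. They also leave open how other groups on the benzyl ring, such as a chlorine atom or a hydroxyl, would carry between the cores, and whether the same holds with an amine or a longer chain in place of the nitrile chain.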